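Swapping Chloro for Dimethylamino on a Shared Core

This account rests on a few compounds, and the source may have more. Where it says the series, first, only, none or still open, it means among the compounds named here.

Three related compounds have been measured in a functional assay on LS174T cells (Homo sapiens) for inhibition, with a stated time of 4 days, tested at 1 uM; a lower number here means a weaker effect, a higher number a stronger effect of the compound at the concentration tested. Compound 1 `Fc1cccc(F)c1C#Cc1nccc2ccccc12` gives 35.4%, compound 2 `Cn1ncc2cc(C#Cc3c(F)cccc3F)ccc21` gives 58.4%, and compound 3 `Fc1cccc(F)c1C#Cc1cnc(Cl)c2ccccc12` gives 48.1%. Among these three numbers, compound 3 holds the second highest value: compound 2 stands above it and compound 1 below it, both by margins that go beyond the usual scatter of repeated measurements.

Compound 4 `CN(C)c1ncc(C#Cc2c(F)cccc2F)c2ccccc12` has not yet been measured. It differs from compound 3 in a single place: dimethylamino in place of chloro on an aromatic carbon. The chloro leaves and a dimethylamino takes its spot on the shared core.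

Among the compounds with values here, no pair of the measured compounds differs from one another in only one place, so nothing among the measured numbers shows how large a step such a swap brings. With that in mind, only a modest step is expected in this assay, without a clear direction, and most likely one that stays within the scatter. The step expected from the swap is a number 0.1 percentage points lower from compound 3 to compound 4 (within the scatter). Compound 4 is therefore estimated to give 48% in this assay, with a range from 28% to 68%.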

Compound 4, a percentage reported as inhibition, at one concentration (the size of the read-out at that concentration, not a potency): 99.5%
Estimate against measurement, compound 4: 51.5 percentage points below, and the stated range ends below it.
By their numbers in this assay, from the lowest: compound 1; then compound 3; then compound 2; then compound 4.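

Among these compounds, the only pair differing in one place shows that replacing chloro with dimethylamino on the aromatic carbon next to the ring nitrogen gives, in this assay, a number 51.4 percentage points higher from compound 3 to compound 4 (beyond the scatter). Within the data shown here, this position is therefore far from neutral: what sits on this carbon can change the read-out greatly, which the earlier compounds could not reveal, as no two of them formed such a pair. Nothing available explains why this swap has so large an effect.

A single swap cannot tell whether the gain needs dimethylamino itself or would also appear with a plain amino group, a methylamino group or a methoxy group on the same carbon. From the compounds shown here alone, the read-out also comes from one concentration, so how the two compounds compare in potency remains open.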